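The source may report more compounds than this note shows. Statements on the series, on what has been measured and on what is new or still open speak of the compounds shown alone.

Measured compounds:
- compound 1, `CCCCCCCCCCCC[C@@H](O)[C@H]1CC[C@H]([C@H](O)CCCCCCCCCCNC(=O)c2cncs2)O1`: 50100 nM
- compound 2, `CCCCCCCCCCCC[C@@H](O)[C@H]1CC[C@H]([C@H](O)CCCCCCCCCCNC(=O)c2ccsc2)O1`: 100000 nM

In a functional assay on SF-539 cells (Homo sapiens) for inhibition, read by colorimetric assay and sulforhodamine B assay, with a stated time of 48 h (a higher number here means a weaker inhibitor of growth, a lower number a stronger inhibitor of growth), compound 1 gives 50100 nM and has the lowest of the two numbers, while compound 2 gives 100000 nM. Within the data shown here, the only step among the measured pair, a 2.0-fold higher number from compound 1 to compound 2 (0.30 log units; within the scatter), is within the scatter. Compound 3, `CCCCCCCCCCCC[C@@H](O)[C@H]1CC[C@H]([C@H](O)CCCCCCCCCCNC(=O)c2ccco2)O1`, differs from compound 1 as follows: furan-2-yl in place of 1,3-thiazol-5-yl on a carbonyl carbon. Among the measured compounds shown here, no measured step carries the same change, and the one step that exchanges the ring on the carbonyl carbon stays within the scatter, so no step beyond the scatter is expected here. For compound 3 the expected value is 60000 nM, within 25000 nM to 150000 nM, meaning an expected step of a 1.2-fold higher number from compound 1 to compound 3 (0.08 log units; within the scatter).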

Compound 3, concentration for 50% growth inhibition: 81300 nM
The estimate for compound 3 lay 1.4-fold (0.13 log units) below the measured number; the range from low to high includes it.
By their numbers in this assay, from the lowest: compounds 1, 3 and 2 (each within the scatter of the next).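

In this assay, the step of a 1.6-fold higher number from compound 1 to compound 3 (0.21 log units; within the scatter) and the step of a 1.2-fold lower number from compound 2 to compound 3 (0.09 log units; within the scatter) show that furan-2-yl, with its single ring oxygen, reads alike with both earlier rings on this carbonyl carbon. Three five-membered aromatic rings, one with nitrogen and sulfur, one with sulfur alone and one with oxygen alone, have now stood at this place with no step beyond the scatter. No measurement shown bears on the reason for this result.

On these data alone, whether a pyridine ring, an amine, a carboxylic acid or a longer chain in place of the ring would give a step beyond the scatter stays open.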